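Adding a Chloro Group to Compound 2

The source may hold more compounds than are shown below. What is called first, only, known or untested is meant among the compounds shown, and "the series" means these compounds.

Compound 1, `CCCNC(=S)NCCC(O)c1ccccc1N`: 31.1%
Compound 2, `CCCNC(=O)NCCC(O)c1ccccc1N`: 19%

Of the compounds shown here, two have been measured in an assay for inhibition of Nitric oxide synthase, inducible (Homo sapiens), read by scintillation counting, with a stated time of 30 min, tested at 1 mM; a higher number here means more inhibition at the concentration tested (going by the name of the read-out), a lower number less inhibition. Compound 1 `CCCNC(=S)NCCC(O)c1ccccc1N` gives 31.1% in this assay, and compound 2 `CCCNC(=O)NCCC(O)c1ccccc1N` gives 19%. Among the measured compounds shown here, the only measured step, a number 12.1 percentage points lower from compound 1 to compound 2 (beyond the scatter), concerns a change on an amine nitrogen and leaves compound 2 as the lower of the two numbers. Compound 3 `CCCNC(=O)NCCC(O)c1cc(Cl)ccc1N` differs from compound 2 by chloro in place of hydrogen on an aromatic carbon. For the measured compounds named here, no measured step touches the aromatic ring, and the step on the amine nitrogen offers no guide to the size or direction of this change. With nothing to point either way, the expected step in this assay is a number 2 percentage points higher from compound 2 to compound 3 (within the scatter), within the scatter. Compound 3 is therefore estimated at 21%, with a range from 5% to 40%.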

Compound 3, a percentage reported as inhibition, at one concentration (the size of the read-out at that concentration, not a potency): 19.6%
Beside the measured number, compound 3's estimate is 1.4 percentage points above it; low and high end bracket the measured number.
By their numbers in this assay, from the lowest: compounds 2 and 3 (each within the scatter of the next); then compound 1.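

In this assay, among the compounds shown here, chloro in place of hydrogen on an aromatic carbon, para to an amino group, gives a number 0.6 percentage points higher from compound 2 to compound 3 (within the scatter) and is the first measured change on the aromatic ring. At this position, chloro therefore produces no difference that this assay can separate from the scatter, unlike the earlier change on the amine nitrogen, whose step lay beyond it. Nothing available explains this result.

As far as these compounds go, whether another group at this same position, such as a methoxy group, a nitrile or a carboxylic acid, would give a step beyond the scatter remains open. So does whether chloro would behave the same way on another aromatic carbon or on the core of compound 1, which carries sulfur where compound 2 carries oxygen.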